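A few compounds are considered here, and "the series" means these few. Any claim that something is new, unique, unknown or untested is made for them only; others in the source may bear on it.

Compound 1 `O=C(CCc1cccc2c1B(O)OC2)Nc1nccs1` - > 100000 nM
Compound 2 `O=C(CCc1cccc2c1B(O)OC2)Nc1ccc(F)cc1` - 720 nM
Compound 3 `O=C(CCc1cccc2c1B(O)OC2)Nc1ccc(Cl)cc1` - 5000 nM

In a functional assay on SK-OV-3 cells (Homo sapiens) for antiproliferative activity, read by MTT assay, with a stated time of 72 h (on this read-out higher numbers stand for weaker inhibition and lower numbers for stronger inhibition), compound 1 stands at > 100000 nM, which is a limit of the assay and not a number. Compound 4 `Cc1ccc(NC(=O)CCc2cccc3c2B(O)OC3)cc1` carries 4-methylphenyl in place of 1,3-thiazol-2-yl on the amide-type nitrogen: 4-methylphenyl in place of 1,3-thiazol-2-yl on an amide-type nitrogen. Two measured swaps of that same group bear on this change, and both were large: an at least 130-fold lower number from compound 1 to compound 2 (2.14 log units; beyond the scatter) and an at least 20-fold lower number from compound 1 to compound 3 (1.30 log units; beyond the scatter). The choice of group on the new ring also matters, as a 6.9-fold higher number from compound 2 to compound 3 (0.84 log units; beyond the scatter) shows. A large step towards a lower number, meaning stronger inhibition, is therefore expected: an at least 50-fold lower number from compound 1 to compound 4 (1.69 log units; beyond the scatter). For compound 4 the estimated value is 2000 nM, with an expected range from 400 nM to 10000 nM.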

Compound 4, half-maximal inhibitory concentration: 860 nM
The estimate for compound 4 lay 2.3-fold (0.37 log units) above the measured number; low and high end bracket the measured number.
By their numbers in this assay, from the lowest: compounds 2 and 4 (each within the scatter of the next); then compound 3. At a limit, above all of these: compound 1.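

Placing 4-methylphenyl on the amide-type nitrogen gives an at least 110-fold lower number from compound 1 to compound 4 (2.06 log units; beyond the scatter), so a ring carrying no halogen also gives a measurable number. That step is only a minimum, because compound 1 stands at a limit and not a number: the limit of > 100000 nM in this assay, at which 1 of the 4 values shown sits. Methyl and fluoro sit level, with a 1.2-fold higher number from compound 2 to compound 4 (0.08 log units; within the scatter), whereas chloro stands apart, with a 5.8-fold lower number from compound 3 to compound 4 (0.76 log units; beyond the scatter), so the two halogens do not behave as one class. Open, from the compounds shown here alone, is whether a methoxy group or an amine on this ring would keep this level, and how a plain phenyl ring would compare.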